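Half-life under a glucuronosyltransferase for an amidoxime series

The source may report more compounds than this note shows. Statements on the series, on what has been measured and on what is new or still open speak of the compounds shown alone.

Measured compounds:
compound 1 `NS(=O)(=O)CC(=O)NCCSc1nonc1/C(=N/O)Nc1ccc(F)c(C(F)F)c1` gives > 3 h
compound 2 `CS(=O)(=O)CC(=O)NCCSc1nonc1/C(=N/O)Nc1ccc(F)c(C(F)F)c1` gives 1.59 h

Going by the values given here, in an ADME assay on isolated protein for pharmacokinetics, with UDP-glucuronosyltransferase 1A9 (Homo sapiens) as the target, read by LC-MS, with a stated time of 60 min, at 37 degrees C, tested at 1 uM, in the presence of a further agent that is not named here (on this read-out lower numbers stand for a shorter-lived compound and higher numbers for a longer-lived compound), compound 2 gives 1.59 h, the only plain number obtained so far. Compound 1 gives > 3 h, which is a limit of the measurement rather than a number (the limit of > 3 h in this assay, at which 1 of the 2 values shown sits). Among the compounds with values here, the one step between measured compounds, an at least 1.8-fold lower number from compound 1 to compound 2 (0.27 log units; that floor lies within the scatter), is a methyl in place of amino on a sulfonyl sulfur, and its floor lies within the scatter.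

Compound 3 `CC1(C(=O)NCCSc2nonc2/C(=N/O)Nc2ccc(F)c(C(F)F)c2)CCN1` differs from compound 2 by a group of 5 heavy atoms (4 carbon, 1 nitrogen; one four-membered non-aromatic ring with 1 hetero atom) in place of a group of 5 heavy atoms (2 carbon, 2 oxygen, 1 sulfur; no ring), on a carbonyl carbon. Within the data shown here, no measured step touches this position in the same way; the step from compound 1 to compound 2 is the only guide, and it shows that a change at the group on the carbonyl carbon can move the number at least modestly. The expected step of a 1.6-fold higher number from compound 2 to compound 3 (0.20 log units; within the scatter) is therefore towards a somewhat longer-lived compound, though not clearly beyond the scatter. Compound 3 is estimated at 2.5 h, within 1.2 h to 5 h.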

Compound 3, half-life: > 3 h
Compound 3: only a limit was reported; the forecaster's own chance of this, stated with the estimate: 35%; middle value at least 1.2-fold (0.07 log units) away from the limit.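

In this assay exchanging the (methylsulfonyl)methyl group on the carbonyl carbon for the group holding a four-membered non-aromatic ring with one hetero atom gives an at least 1.8-fold higher number from compound 2 to compound 3 (0.27 log units; that floor lies within the scatter) and shows that no sulfonyl group is needed at this position for a compound to reach the limit of the measurement. The reading for compound 3 is a limit and not a number, and it is the same limit that compound 1 reaches with its quite different group: the limit of > 3 h in this assay, at which 2 of the 3 values shown sit. The step between compound 1 and compound 3 cannot be read.

Going by these compounds, how far either compound lies past that limit remains open. So does whether a plain open-chain amine, a carboxylic acid or a longer chain on the same carbonyl carbon would also reach it.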